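The source may report more compounds than this note shows. Statements on the series, on what has been measured and on what is new or still open speak of the compounds shown alone.

Measured so far in a functional assay on cells (Platelet, Homo sapiens) for inhibition; a higher number here means a weaker inhibitor, a lower number a stronger inhibitor:
compound 1 `CCOC(=O)c1ccc(-c2nn(C)c3ccccc23)cc1` gives 270 nM
compound 2 `CCOC(=O)c1ccc(-c2nn(Cc3ccc(Cl)cc3)c3ccccc23)cc1` gives 120 nM

For the measured compounds named here, compound 2 holds the lowest of the two numbers; the only other compound, compound 1, sits higher by the step of a 2.3-fold lower number from compound 1 to compound 2 (0.35 log units; beyond the scatter). Compound 3 `CCOC(=O)c1ccc(-c2nn(-c3ccoc3)c3ccccc23)cc1` is not yet measured. Its change from compound 2 is furan-3-yl in place of 4-chlorobenzyl on an aromatic nitrogen. Going by the values given here, only the step from compound 1 to compound 2 bears on this position, and it was modest; the 4-chlorobenzyl gained there now leaves, and a smaller furan-3-yl enters. Compound 3 is therefore expected to give back part of that gain, with an expected step of a 1.7-fold higher number from compound 2 to compound 3 (0.22 log units; within the scatter). The estimate for compound 3 is 200 nM, within 90 nM to 450 nM.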

Compound 3, half-maximal inhibitory concentration: 580 nM
Compound 3: the middle estimate sits 2.9-fold (0.46 log units) below what was measured, and the stated range ends below it.
By their numbers in this assay, from the lowest: compound 2; then compound 1; then compound 3.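

In this assay, furan-3-yl on the aromatic nitrogen gives a 4.8-fold higher number from compound 2 to compound 3 (0.68 log units; beyond the scatter) and a 2.1-fold higher number from compound 1 to compound 3 (0.33 log units; beyond the scatter) and so stands behind both 4-chlorobenzyl and methyl. The position therefore moves the number in both directions from methyl, and an aromatic ring in this place does not by itself bring the lower number. No measured finding bears on why furan-3-yl reads this way. Still open, as far as these compounds go, is whether the lower number of 4-chlorobenzyl depends on the chlorine or on the saturated chain carbon, which plain benzyl and directly bound phenyl would separate. From the compounds shown here alone, how a chain ending in an amine would read here is also open.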